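Lengthening the Methoxy Group of Compound 2

A few compounds are considered here, and "the series" means these few. Any claim that something is new, unique, unknown or untested is made for them only; others in the source may bear on it.

In a functional assay on brain (Rattus norvegicus, strain Wistar) for inhibition (a higher number here means a weaker inhibitor, a lower number a stronger inhibitor), compound 1 (`Cc1[nH]c(=O)n(C2CCCCC2)c1-c1ccccc1`) gives 47600 nM as its half-maximal inhibitory concentration, compound 2 (`COc1ccc(-c2c(C)[nH]c(=O)n2C2CCCCC2)cc1`) gives 20400 nM and compound 3 (`CCCCCCCCc1ccc(-c2c(C)[nH]c(=O)n2C2CCCCC2)cc1`) gives 10300 nM on the same read-out. Compound 2 thus lies clearly below compound 1 yet within the scatter of compound 3.

Compound 4 (`CCCCCCCCCCOc1ccc(-c2c(C)[nH]c(=O)n2C2CCCCC2)cc1`) has not yet been measured. It differs from compound 2 by nonyl in place of hydrogen on a saturated chain carbon bound to an oxygen on an aromatic ring in the form of nonyl in place of hydrogen on a saturated chain carbon bound to an oxygen on an aromatic ring.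

For the measured compounds named here, no measured step alters that chain directly. The nearest evidence is a 2.3-fold lower number from compound 1 to compound 2 (0.37 log units; beyond the scatter) and a 4.6-fold lower number from compound 1 to compound 3 (0.66 log units; beyond the scatter) on the aromatic carbon, both modest, whereas octyl in place of methoxy gives a 2.0-fold lower number from compound 2 to compound 3 (0.30 log units; within the scatter) and so no change beyond the scatter. A modest further drop is therefore expected, the estimated step being a 2.3-fold lower number from compound 2 to compound 4 (0.36 log units; beyond the scatter) in this assay with considerable uncertainty. For compound 4 the estimated value is 9000 nM within an expected range from 3000 nM to 25000 nM on this read-out.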

Compound 4, half-maximal inhibitory concentration: 10500 nM
Beside the measured number, compound 4's estimate is 1.2-fold (0.07 log units) below it; measured number inside the range.
By their numbers in this assay, from the lowest: compounds 3, 4 and 2 (each within the scatter of the next); then compound 1.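

In this assay, nonyl in place of hydrogen on a saturated chain carbon bound to an oxygen on an aromatic ring gives a 1.9-fold lower number from compound 2 to compound 4 (0.29 log units; within the scatter) and so no change beyond the scatter. For the compounds shown here, the earlier compounds showed only changes on the aromatic carbon, whereas this is the first reading at the chain on the oxygen itself, and the change from methyl to decyl at this position leaves the number within the scatter of compound 2. No measurement shown here offers an explanation for this result.

With only methyl and decyl at this position, the compounds shown leave open how intermediate chains such as butyl or hexyl would read. They also leave open whether a chain carrying an amine or a carboxylic acid would move the number beyond the scatter.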